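From a Five-Membered to a Seven-Membered Amine Ring

The compounds below may be only part of what the source reports. "The series", "measured", "known", "first", "only" and "open" are said of these compounds alone.

In a functional assay on MCF7 cells (Homo sapiens) for antiproliferative activity, read by CellTiter-Glo, with a stated time of 5 days (on this read-out higher numbers stand for weaker inhibition and lower numbers for stronger inhibition), compound 2 `CC1=C(c2cccc(O)c2)C(c2ccc(OC[C@H](C)N3CCCC3)cc2)Oc2ccc(O)cc21` gives 0.2 nM while compound 1 `CC1=C(c2cccc(O)c2)C(c2ccc(OC[C@H](C)N3CCCCC3)cc2)Oc2ccc(O)cc21` gives 0.1 nM as its number, and these two lie within the usual scatter of each other. Compound 3 `CC1=C(c2cccc(O)c2)C(c2ccc(OC[C@H](C)N3CCCCCC3)cc2)Oc2ccc(O)cc21` keeps the shared core and carries azepan-1-yl in place of pyrrolidin-1-yl on a saturated chain carbon bound to two saturated chain carbons. For the measured compounds named here, the one measured step that bears on this, pyrrolidin-1-yl in place of piperidin-1-yl at the same place, is a 2.0-fold higher number from compound 1 to compound 2 (0.30 log units; within the scatter) so no shift beyond the scatter is expected in this assay for azepan-1-yl, though that group has not yet been measured here. The expected step is no change at the digits printed from compound 2 to compound 3 (within the scatter) and it remains an estimate. For compound 3 the estimated value is 0.2 nM with an expected range of 0.07 nM to 0.8 nM around it.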

Compound 3, half-maximal inhibitory concentration: 0.2 nM
Compound 3: middle estimate and measured number agree at the digits printed, within the range that was stated.
By their numbers in this assay, from the lowest: compounds 1, 2 and 3 (each within the scatter of the next).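

In this assay there is no change at the digits printed from compound 2 to compound 3 (within the scatter) and a 2.0-fold higher number from compound 1 to compound 3 (0.30 log units; within the scatter) on going to azepan-1-yl. Until now only the five-membered and six-membered rings could be compared; the seven-membered ring extends that comparison, and all three amine rings on this saturated chain carbon bound to two saturated chain carbons give numbers that cannot be told apart, so within these compounds ring size has no readable effect. Nothing available offers an explanation for this flat result. Still open, as far as these compounds go, is whether a ring carrying a second hetero atom, such as morpholin-4-yl, would behave the same way at this place. An open-chain amine such as dimethylamino, with no ring at all, poses the same question.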